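The source may report more compounds than this note shows. Statements on the series, on what has been measured and on what is new or still open speak of the compounds shown alone.

The values below come from a functional assay on HCT-116 cells (Homo sapiens) for inhibition, read by colorimetric assay, with a stated time of 3 days (a higher number here means a weaker inhibitor, a lower number a stronger inhibitor), and stand as measured

Compound 1 `COc1ccc2sc(NC(=O)CCCCCCNC(=O)C(O)(O)C(F)(F)F)nc2c1` gives 2180 nM
Compound 2 `O=C(CCCCCCNC(=O)C(O)(O)C(F)(F)F)Nc1ccc(Br)cc1` gives 3130 nM
Compound 3 `O=C(CCCCCCNC(=O)C(O)(O)C(F)(F)F)Nc1ccc(S(F)(F)(F)(F)F)cc1` gives 9110 nM

Compound 3 has the highest number of the three and is the weakest inhibitor among them. Compound 4 `Cc1ccc(S(=O)(=O)Nc2ccc(NC(=O)CCCCCCNC(=O)C(O)(O)C(F)(F)F)cc2)cc1` differs from it by one exchange (a group of 11 heavy atoms (7 carbon, 1 nitrogen, 2 oxygen, 1 sulfur; one six-membered aromatic ring of carbon only) in place of a group of 6 heavy atoms (5 fluorine, 1 sulfur; no ring), on an aromatic carbon). Among the compounds with values here, only one measured step touches this place (a 2.9-fold higher number from compound 2 to compound 3 (0.46 log units; beyond the scatter)), and it was modest. Within the data shown here, no measured compound carries the entering group, so that step is a thin guide to size or direction. With compound 2 at 3130 nM as the nearest value, a modest move toward a lower number is expected in this assay but remains uncertain. The expected change is small (a 2.3-fold lower number from compound 3 to compound 4 (0.36 log units; beyond the scatter)). For compound 4 the estimated value is 4000 nM (range 1500 nM to 11000 nM).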

Compound 4, half-maximal inhibitory concentration: 17200 nM
For compound 4 the middle estimate is 4.3-fold (0.63 log units) below the measured one; measured number outside the range, above it.
By their numbers in this assay, from the lowest: compounds 1 and 2 (each within the scatter of the next); then compounds 3 and 4 (each within the scatter of the next).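

In this assay the exchange of bromo for ((4-methylphenyl)sulfonyl)amino gives a 5.5-fold higher number from compound 2 to compound 4 (0.74 log units; beyond the scatter) and so brings no gain over bromo at this aromatic carbon. In place of the group of five fluorines and one sulfur, the same entering group gives a 1.9-fold higher number from compound 3 to compound 4 (0.28 log units; within the scatter) and cannot be told apart from it here. No available evidence accounts for these results. The compounds shown leave open whether the methylphenyl ring matters, as a plain methylsulfonylamino group could show. They also leave open how an amine or a carboxylic acid at this place would compare with bromo.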